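This account rests on a few compounds, and the source may have more. Where it says the series, first, only, none or still open, it means among the compounds named here.

Measured compounds:
compound 1 `CCc1cc(Br)c(S(C)(=O)=O)cc1C(=O)N=C(N)N`: 41 nM
compound 2 `CCN(CC)Cc1cc(Br)c(S(C)(=O)=O)cc1C(=O)N=C(N)N`: 9500 nM
compound 3 `CCCc1cc(C)c(C(=O)N=C(N)N)cc1S(C)(=O)=O`: 5.7 nM

In a functional assay for inhibition of sodium/hydrogen exchanger (Oryctolagus cuniculus) (a lower number here means a stronger inhibitor, a higher number a weaker inhibitor), compound 3 gives the lowest number of the three; compound 1 stands nearest to it and compound 2 furthest. Within the data shown here, only one step between compounds differing in a single place has been measured: a 230-fold higher number from compound 1 to compound 2 (2.36 log units; beyond the scatter), a large weakening. The unmeasured compound 4 `Cc1cc(-c2cc(Cl)cc(Cl)c2)c(S(C)(=O)=O)cc1C(=O)N=C(N)N` differs from compound 3 by 3,5-dichlorophenyl in place of propyl on an aromatic carbon. Among the measured compounds shown here, the measured step concerns a diethylamino group entering on a saturated chain carbon bound to an aromatic carbon; the change to compound 4 places a 3,5-dichlorophenyl on an aromatic carbon ortho to a methylsulfonyl group, and no measured pair shows an aryl group entering anywhere. The known step therefore bears on the new one only loosely, as a sign that a much larger group entering the core can cost a great deal. For the measured compounds named here, with no direct precedent, a moderate weakening is expected in this assay, the expected step being a 4.4-fold higher number from compound 3 to compound 4 (0.64 log units; beyond the scatter). Compound 4 is expected to give 25 nM, between 4 nM and 200 nM.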

Compound 4, half-maximal inhibitory concentration: 130 nM
Estimate against measurement, compound 4: 5.2-fold (0.72 log units) below, within the range that was stated.
By their numbers in this assay, from the lowest: compound 3; then compound 1; then compound 4; then compound 2.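

In this assay, 3,5-dichlorophenyl in place of propyl on the aromatic carbon ortho to a methylsulfonyl group gives a 23-fold higher number from compound 3 to compound 4 (1.36 log units; beyond the scatter), a large weakening, yet compound 4 still gives a measurable 130 nM. Among these compounds, this is the first step in which an aryl group enters, and it shows that the number at this aromatic carbon responds strongly to the group carried there, which the diethylamino step on a saturated chain carbon could not show. Nothing available explains the size of this step.

On these data alone, whether the loss belongs to the ring itself or to its two chlorines stays open, and an unsubstituted phenyl or a 3-chlorophenyl at this carbon would separate the two. As far as these compounds go, how an amine such as piperidine, or a longer chain such as butyl, compares with propyl at the same carbon also remains unknown.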